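A few compounds are considered here, and "the series" means these few. Any claim that something is new, unique, unknown or untested is made for them only; others in the source may bear on it.

In a functional assay on MDA-MB-231 cells (Homo sapiens) for antiproliferative activity, read by MTT assay, with a stated time of 24 h (on this read-out lower numbers stand for stronger inhibition and higher numbers for weaker inhibition), compound 1 `O=C(NNc1cccc(Cl)c1)c1ccc(NS(=O)(=O)c2cnc(O)nc2O)cc1` gives 17400 nM. Compound 2 `O=C(NNC(=O)c1ccccc1F)c1ccc(NS(=O)(=O)c2cnc(O)nc2O)cc1` gives > 20000 nM, which is a limit of the assay and not a number. Compound 2 therefore has no exact place on the scale, and its position is known only as the limit of > 20000 nM in this assay, at which 1 of the 2 values shown sits.

Compound 3 `O=C(NNC(=O)c1ccc(NS(=O)(=O)c2cnc(O)nc2O)cc1)c1ccc(F)cc1` is built from the same atoms as compound 2, joined differently. It carries 4-fluorophenyl in place of 2-fluorophenyl on a carbonyl carbon.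

For the measured compounds named here, only one measured step bears on this change, and it bears only indirectly: an at least 1.1-fold higher number from compound 1 to compound 2 (0.06 log units; that floor lies within the scatter). Going by the values given here, that step swaps one group for a different one, so no measurement yet tests the 2-fluorophenyl to 4-fluorophenyl change itself. Resting on that small step, no shift beyond the usual scatter is expected in this assay, in either direction.

The estimated change is a number no higher from compound 2 to compound 3 (the limit leaves the size open), and the assay may again report only a limit. For compound 3 the expected value is 20000 nM, with an estimated range from 8000 nM to 40000 nM.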

Compound 3, half-maximal inhibitory concentration: > 20000 nM
Compound 3: no number, only a limit; the forecaster's own chance of this, stated with the estimate: 55%; the middle value lies on the limit itself.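

In this assay compound 3 gives > 20000 nM, which is a limit and not a number. Placing 4-fluorophenyl in place of 2-fluorophenyl on a carbonyl carbon therefore gives a step that cannot be read, because both compounds stand at the same limit: the limit of > 20000 nM in this assay, at which 2 of the 3 values shown sit.

For the compounds shown here, the one readable comparison is an at least 1.1-fold higher number from compound 1 to compound 3 (0.06 log units; that floor lies within the scatter), so it does not establish a real difference between these two compounds, and the new result adds a second (fluorophenyl)carbonyl compound without a number.

On these data alone, how far compound 2 and compound 3 differ in this assay stays open, since neither has a place on the scale. As far as these compounds go, it also stays open whether a different group on that carbonyl carbon, such as an amine or a carboxylic acid, would give a measurable value in this assay.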